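The source may hold more compounds than are shown below. What is called first, only, known or untested is meant among the compounds shown, and "the series" means these compounds.

Measured so far:
compound 1 `Brc1ccc(Cn2ccc3nc(-c4ccccc4)nc-3c2)cc1`: 83000 nM
compound 2 `Clc1ccc(Cn2ccc3nc(-c4ccccc4)nc-3c2)cc1Cl`: 71000 nM

In an ADME assay on MDBK cells (Bos taurus) for cytotoxicity (a higher number here means that more compound is tolerated, a lower number that less compound is tolerated), compound 2 gives 71000 nM; compound 1 gives 83000 nM, and the two sit within the scatter of each other, compound 2 at the lower end. Compound 3 `c1ccc(-c2nc3ccn(Cc4ccncc4)cc-3n2)cc1` is not yet measured. It differs from compound 2 thus: pyridin-4-yl in place of 3,4-dichlorophenyl on a saturated chain carbon bound to an aromatic nitrogen. For the measured compounds named here, the only measured step at this position, a 1.2-fold lower number from compound 1 to compound 2 (0.07 log units; within the scatter), stayed within the scatter, so for the change to pyridin-4-yl no step beyond the scatter is expected in this assay. The expected step is a 1.3-fold higher number from compound 2 to compound 3 (0.10 log units; within the scatter). Compound 3 is estimated at 90000 nM, with a range from 45000 nM to 180000 nM.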

Compound 3, half-maximal cytotoxic concentration: > 100000 nM
Compound 3: only a limit was reported; the forecaster's own chance of this, stated with the estimate: 30%; middle value at least 1.1-fold (0.04 log units) from the limit.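

In this assay compound 3 gives only a limit, > 100000 nM. With pyridin-4-yl, the only ring shown here with a hetero atom, this position on a saturated chain carbon bound to an aromatic nitrogen shows no sign of less compound being tolerated: an at least 1.4-fold higher number from compound 2 to compound 3 (0.14 log units; that floor lies within the scatter) and an at least 1.2-fold higher number from compound 1 to compound 3 (0.08 log units; that floor lies within the scatter). Both steps are floors, so whether either passes the scatter cannot be told, and they are set by a limit rather than a number: the limit of > 100000 nM in this assay, at which 1 of the 3 values shown sits.

From the compounds shown here alone, the true size of the change remains open. Also open, going by these compounds, is whether an amine, a carboxylic acid or a longer chain at this position would keep the same picture.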